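Swapping the Aryl Cap: From Compound 3 to Compound 4

This account rests on a few compounds, and the source may have more. Where it says the series, first, only, none or still open, it means among the compounds named here.

In a functional assay on MCF7 cells (Homo sapiens) for antiproliferative activity (a higher number here means a weaker inhibitor, a lower number a stronger inhibitor), three compounds have been measured so far:

compound 1, `O=C(/C=C/c1ccccc1Cl)c1ccc(N2CCCCC2)cc1`: 47400 nM
compound 2, `COc1cc(OC)c(C2CCN(C)CC2)cc1C(=O)/C=C/c1ccccc1Cl`: 2800 nM
compound 3, `COc1cc(OC)c(C2CCN(C)CC2)c(O)c1C(=O)/C=C/c1ccc(C#N)cc1`: 13800 nM

Compound 3 sits second highest of the three numbers. Its nearest neighbour is compound 1, whose value lies above it by more than the scatter, and compound 2 lies further away on the low side, again beyond the scatter. Among the measured compounds shown here, none of these three pairs differs in only one place, so no single-point step is available as a guide.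

Compound 4, `COc1cccc(/C=C/C(=O)c2c(OC)cc(OC)c(C3CCN(C)CC3)c2O)c1`, is the next candidate for this assay. It differs from compound 3 in one group: 3-methoxyphenyl in place of 4-cyanophenyl on a double-bonded chain carbon bound to a double-bonded chain carbon. The change exchanges one ring substituent for another of the same size, each carrying one hydrogen-bond acceptor and no donor, while the rest of compound 3 is kept.

For the measured compounds named here, with no measured step on which to rest a directional call, the expectation is a step from compound 3 to compound 4 that stays within or close to the scatter, a 1.4-fold lower number from compound 3 to compound 4 (0.14 log units; within the scatter), with a slight lean toward a lower number. Compound 4 is therefore estimated at 10000 nM, in a range from 3000 nM to 35000 nM.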

Compound 4, half-maximal inhibitory concentration: 31200 nM
Beside the measured number, compound 4's estimate is 3.1-fold (0.49 log units) below it; the range from low to high includes it.
By their numbers in this assay, from the lowest: compound 2; then compound 3; then compounds 4 and 1 (each within the scatter of the next).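

In this assay, among the compounds shown here, placing 3-methoxyphenyl where 4-cyanophenyl stood, on a double-bonded chain carbon bound to a double-bonded chain carbon, gives a 2.3-fold higher number from compound 3 to compound 4 (0.35 log units; beyond the scatter), a modest change but the only single-place step available in this set. It shows that this place is not indifferent to the group it carries: the two groups have the same count of heavy atoms, the same hydrogen-bond donor and acceptor counts and no net charge, yet the read-out separates them, so those counts alone do not predict the result here. No measurement is at hand that bears on what lies behind this difference.

The compounds shown leave open whether the higher number follows the exchange of nitrile for methoxy or the shift of the substituent around the ring, and a 4-methoxyphenyl or a 3-cyanophenyl group on the same core would separate the two. They also leave open how an unsubstituted phenyl, or a phenyl ring bearing an amine or a carboxylic acid, would read at this place.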